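Swapping one side group on a growth inhibitor

The source may hold more compounds than are shown below. What is called first, only, known or untested is meant among the compounds shown, and "the series" means these compounds.

In a functional assay on MV4-11 cells (Homo sapiens) for antiproliferative activity, read by CellTiter-Glo, with a stated time of 72 h (a lower number here means a stronger inhibitor of growth, a higher number a weaker inhibitor of growth), compound 1 (`CC(C)(C)OC(=O)Nc1nc(-c2cc(F)ncc2Cl)cs1`) gives > 10000 nM as a limit and not a number. Compound 2 (`COCC(=O)N[C@H]1CC[C@H](Nc2cc(-c3csc(NCC4CCOCC4)n3)c(Cl)cn2)CC1`) gives > 10000 nM as a limit too. Compound 3 (`COCCN[C@H]1CC[C@H](Nc2cc(-c3csc(OCC4CCOCC4)n3)c(Cl)cn2)CC1`) gives 570 nM in this assay and is the only one of the three with an actual number. Compound 4 (`COCCN[C@H]1CC[C@H](Nc2cc(-c3csc(NCC4CCCCC4)n3)c(Cl)cn2)CC1`) carries (cyclohexylmethyl)amino in place of (oxan-4-yl)methoxy on an aromatic carbon. Going by the values given here, no measured pair shows this change on its own, and no step beyond the usual scatter is expected in this assay for it. The estimated step (a 1.3-fold lower number from compound 3 to compound 4 (0.10 log units; within the scatter)) is correspondingly small. The expected value for compound 4 is 450 nM (expected range 90 nM to 2500 nM).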

Compound 4, concentration for 50% growth inhibition: 820 nM
Compound 4: middle estimate off by 1.8-fold (0.26 log units), on the low side; low and high end bracket the measured number.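

In this assay, the swap gives a 1.4-fold higher number from compound 3 to compound 4 (0.16 log units; within the scatter) and so the two groups cannot be told apart at this place on the five-membered aromatic ring. Going by these compounds alone, this is the first comparison here between two real numbers. Compound 1 and compound 2 each give only a limit, which offers no number to compare: the limit of > 10000 nM in this assay, at which 2 of the 4 values shown sit.

As far as these compounds go, the swap changes the linking atom and the ring atom together, so their separate contributions remain unknown. From the compounds shown here alone, how a piperidine ring or a carboxylic acid would behave at this place also remains open.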